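Carbamate series: chloro in place of methoxy

The source may report more compounds than this note shows. Statements on the series, on what has been measured and on what is new or still open speak of the compounds shown alone.

Among the compounds with values here, compound 1 `COc1ccc(OC(=O)Nc2ccc([Se]C#N)cc2)cc1` and compound 2 `O=C(Nc1ccc([Se][Se]c2ccc(NC(=O)Oc3ccc(F)cc3)cc2)cc1)Oc1ccc(F)cc1` are the two measured members. In a functional assay on PC-3 cells (Homo sapiens) for cytotoxicity, read by MTT assay, with a stated time of 72 h (a higher number here means a weaker inhibitor of growth, a lower number a stronger inhibitor of growth), compound 1 gives 44600 nM, and in this assay compound 2 gives 31300 nM. Compound 1 stands at the top of the two numbers, but its gap to compound 2 lies within the scatter, so the two values show no separation between them. Within the data shown here, no step between measured compounds that differ in one place is available, and compound 2 differs from compound 1 in more than one place, so the measured pair gives no guide to a single substitution.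

Compound 3 `N#C[Se]c1ccc(NC(=O)Oc2ccc(Cl)cc2)cc1` differs from compound 1 by chloro in place of methoxy on an aromatic carbon. Among the measured compounds shown here, nothing among the measured compounds shows how this exchange moves the number in this assay. The expectation is therefore a step of a 1.2-fold lower number from compound 1 to compound 3 (0.07 log units; within the scatter) that stays close to the scatter, with no clear direction. Compound 3 is estimated at 38000 nM in this assay, with a range from 15000 nM to 95000 nM.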

Compound 3, concentration for total growth inhibition: 18700 nM
Compound 3: middle estimate off by 2.0-fold (0.31 log units), on the high side, and the stated range covers the measured number.
By their numbers in this assay, from the lowest: compounds 3, 2 and 1 (each within the scatter of the next, the first and the last beyond it).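

In this assay, within the data shown here, chloro in place of methoxy on the aromatic carbon para to a large group gives the first single-place step, a 2.4-fold lower number from compound 1 to compound 3 (0.38 log units; beyond the scatter), modest in size but beyond the scatter. The number therefore responds to the group at this position, which the earlier pair could not show, as compound 2 differs from compound 1 in more than one place. The step also shows that a single chlorine atom with no hydrogen-bond acceptor can replace the methoxy group, with its carbon, oxygen and one acceptor, without any loss in this read-out, though no measurement at hand explains the shift.

From the compounds shown here alone, a single pair cannot separate what chloro brings from what leaving methoxy removes, and the trend at this position remains open for groups such as bromo, trifluoromethyl, an amine or a carboxylic acid. Going by these compounds, it also remains open whether the same exchange would move the number by a similar step on the core of compound 2, where the carbamate arms are joined through two selenium atoms.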